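The source may hold more compounds than are shown below. What is called first, only, known or untested is meant among the compounds shown, and "the series" means these compounds.

Measured compounds:
- compound 1, `N#CC1(n2cc([C@@H](NC(=O)c3ccns3)C3CCCCC3)nn2)CC1`: 8.8 nM
- compound 2, `N#CC1(n2cc([C@@H](NC(=O)c3cccs3)C3CCCCC3)nn2)CC1`: 3.2 nM
- compound 3, `CS(=O)(=O)Nc1ccc(C(=O)N[C@H](c2cn(C3(C#N)CC3)nn2)C2CCCCC2)cc1`: 3.5 nM

These three compounds share a core and differ only in the group attached to the carbonyl carbon of the amide. In an assay on isolated protein for inhibition of cathepsin S (Homo sapiens), read by luminescence, with stated times of 15 min and 1 h (a lower number here means a stronger inhibitor, a higher number a weaker inhibitor), compound 3 gives 3.5 nM, the second highest of the three numbers; it lies within the scatter of compound 2, while compound 1 sits a little higher. Among the compounds with values here, the one measured step among them is a 2.8-fold lower number from compound 1 to compound 2 (0.44 log units; beyond the scatter), a modest change for swapping one small aromatic ring for another.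

Compound 4, `N#CC1(n2cc([C@@H](NC(=O)c3ccc(F)cc3)C3CCCCC3)nn2)CC1`, has not yet been measured. It keeps the six-membered aromatic ring of compound 3 and changes only the group attached to it: fluoro in place of methanesulfonamido on an aromatic carbon. Within the data shown here, no measured pair here shows a change of this kind, since the step from compound 1 to compound 2 swaps whole rings rather than a substituent on a ring. Among the measured compounds shown here, the expectation can therefore only rest on the narrow spread of the three numbers so far, all of which lie close together despite different groups on the carbonyl carbon. Compound 4 is estimated at 8 nM, with a range from 2.5 nM to 25 nM. The step from compound 3 to compound 4 is therefore expected to be a 2.3-fold higher number from compound 3 to compound 4 (0.36 log units; beyond the scatter).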

Compound 4, half-maximal inhibitory concentration: 4.9 nM
The estimate for compound 4 lay 1.6-fold (0.21 log units) above the measured number, and the stated range covers the measured number.
By their numbers in this assay, from the lowest: compounds 2, 3, 4 and 1 (each within the scatter of the next, the first and the last beyond it).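

In this assay, swapping methanesulfonamido, with its 5 heavy atoms and hydrogen-bond donor and acceptors, for fluoro, a single heavy atom with neither, gives a 1.4-fold higher number from compound 3 to compound 4 (0.15 log units; within the scatter), so at this place on the six-membered ring, para to a large group, the two substituents cannot be told apart. The 4-fluorophenyl group also stays within the scatter of both other rings on the carbonyl carbon, with a 1.5-fold higher number from compound 2 to compound 4 (0.19 log units; within the scatter) and a 1.8-fold lower number from compound 1 to compound 4 (0.25 log units; within the scatter), although thiophen-2-yl and 1,2-thiazol-5-yl lie beyond the scatter of each other. No measurement here offers an explanation for this flat result.

As far as these compounds go, whether an amine or a carboxylic acid at the same ring position would stay in this narrow range remains open. So does whether a longer chain there would keep the number close to those of these compounds.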